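Replacing the 4-hydroxybut-1-yn-1-yl group of compound 3

This account rests on a few compounds, and the source may have more. Where it says the series, first, only, none or still open, it means among the compounds named here.

In a functional assay on Jurkat cells (Homo sapiens) for cytotoxicity, read by MTT assay, with a stated time of 24 h (a higher number here means that more compound is needed for the effect, a lower number that less compound is needed), compound 3 (`CCOC(=O)c1cc(C#CCCO)c2cc(OC)ccc2n1`) gives 123000 nM, level with compound 2 (`CCOC(=O)c1cc([Se]c2ccc(F)cc2)c2cc(OC)ccc2n1`) at 134000 nM, while compound 1 (`CCCCC#Cc1cc(C(=O)OCC)nc2ccc(OC)cc12`) gives 15900 nM. Compound 4 (`CCOC(=O)c1cc([Se]c2ccccc2C)c2cc(OC)ccc2n1`) changes compound 3 in one place: a group of 8 heavy atoms (7 carbon, 1 selenium; one six-membered aromatic ring of carbon only) in place of a group of 5 heavy atoms (4 carbon, 1 oxygen; no ring), on an aromatic carbon. The closest evidence is a 1.1-fold lower number from compound 2 to compound 3 (0.04 log units; within the scatter), where a comparable selenium-containing group gives way to the same 4-hydroxybut-1-yn-1-yl group. The steps of an 8.4-fold higher number from compound 1 to compound 2 (0.93 log units; beyond the scatter) and a 7.7-fold higher number from compound 1 to compound 3 (0.89 log units; beyond the scatter) are beyond the scatter, but they involve a chain that neither compound 3 nor compound 4 carries. The expected result is a 1.0-fold higher number from compound 3 to compound 4 (0.01 log units; within the scatter), so no step beyond the scatter is expected in this assay. Compound 4 is estimated at 125000 nM, with an expected range of 50000 nM to 300000 nM.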

Compound 4, half-maximal effective concentration: 14900 nM
The estimate for compound 4 lay 8.4-fold (0.92 log units) above the measured number, outside the stated range (below it).
By their numbers in this assay, from the lowest: compounds 4 and 1 (each within the scatter of the next); then compounds 3 and 2 (each within the scatter of the next).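

In this assay the group carried on selenium proves decisive: 2-methylphenyl in place of 4-fluorophenyl gives a 9.0-fold lower number from compound 2 to compound 4 (0.95 log units; beyond the scatter) and so a selenium link alone does not fix the number at this position. Replacing 4-hydroxybut-1-yn-1-yl with the same selenium group gives an 8.3-fold lower number from compound 3 to compound 4 (0.92 log units; beyond the scatter) whereas the comparison with the chain of compound 1 gives a 1.1-fold lower number from compound 1 to compound 4 (0.03 log units; within the scatter) and shows that a selenium group and a triple-bonded chain can read alike here. No measurement shown explains why the two aryl groups differ.

Still open, from the compounds shown here alone, is whether the shift follows the methyl, its place on the ring or the loss of fluorine. A plain phenyl on selenium, or an amine on that ring, would help to separate these.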